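Removing the trifluoromethyl group in compound 3

The source may report more compounds than this note shows. Statements on the series, on what has been measured and on what is new or still open speak of the compounds shown alone.

compound 1 `O=C(O)CCNC(=O)c1ccc(C(Oc2ccc(-n3cc(C(F)(F)F)cn3)cc2)C2CCC2)cc1` with 2.6
compound 2 `CCCC(Oc1ccc(-n2cc(C(F)(F)F)c(C)n2)cc1)c1ccc(C(=O)NCCC(=O)O)cc1` with 2.8

In a physicochemical assay for lipophilicity, using the shake flask method, at pH 7.4 (a higher number here means a more lipophilic compound, a lower number a more polar compound), compound 2 gives 2.8 and compound 1 gives 2.6 within the scatter of each other, so the two cannot be told apart.

Compound 3 `CCCC(Oc1ccc(-n2cc(C)cn2)cc1)c1ccc(C(=O)NCCC(=O)O)cc1` has not yet been measured. It differs from compound 2 in one place, as 4-methyl-1H-pyrazol-1-yl in place of 3-methyl-4-(trifluoromethyl)-1H-pyrazol-1-yl on an aromatic carbon shows, with 4-methyl-1H-pyrazol-1-yl in place of 3-methyl-4-(trifluoromethyl)-1H-pyrazol-1-yl on an aromatic carbon, para to a large group.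

Among the measured compounds shown here, no two measured compounds differ in a single place, so the data hold no direct step for this change and the expectation rests on the structural change alone. Taking compound 2 at 2.8 as the starting point, a fall beyond the scatter is expected, with the loss of the trifluoromethyl group as its only ground. The estimated step is a number 0.90 log units lower from compound 2 to compound 3 (beyond the scatter) on this reading. For compound 3 the estimate is 1.9 with an expected range from 1.4 to 2.4 when it is measured.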

Compound 3, distribution coefficient: 2.1
Compound 3: the middle estimate sits 0.20 log units below what was measured; measured number inside the range.
By their numbers in this assay, from the lowest: compound 3; then compounds 1 and 2 (each within the scatter of the next).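

In this assay the series now holds its first step that changes one place alone, on an aromatic carbon para to a large group, and it reads a number 0.70 log units lower from compound 2 to compound 3 (beyond the scatter) as 4-methyl-1H-pyrazol-1-yl takes the place of 3-methyl-4-(trifluoromethyl)-1H-pyrazol-1-yl. Compound 1 and compound 2 differ in more than one place and stand within the scatter of each other, and that pair gave no such reading; this step shows that the distribution coefficient can move beyond the scatter with the group at this position, the leaving group having 10 heavy atoms and the entering one 6, with the counts of hydrogen-bond donors and acceptors unchanged. Nothing measured here accounts for the size of the step.

The step exchanges the whole group, so the compounds shown do not separate the loss of the trifluoromethyl from the different placing of the methyl, and they leave open what a chlorine atom or a nitrile in place of the trifluoromethyl would give. Also open, from the compounds shown here alone, is whether a step of this size would hold on the core of compound 1.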